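Removing One of Two Fluoro Groups from Compound 3

The source may hold more compounds than are shown below. What is called first, only, known or untested is meant among the compounds shown, and "the series" means these compounds.

Of the compounds shown here, three sharing one core have been measured in a functional assay on MCF7 cells (Homo sapiens) for inhibition, in the absence of a further agent; a lower number here means a stronger inhibitor, a higher number a weaker inhibitor. Compound 1 `Nc1ccc(-c2cc(=O)c3c(N)c(Cl)ccc3o2)cc1` gives 3.9 nM. Compound 2 `Nc1ccc(-c2cc(=O)c3c(N)cccc3o2)cc1` gives 7.3 nM. Compound 3 `Nc1ccc(-c2cc(=O)c3c(N)c(F)cc(F)c3o2)cc1` gives 6 nM. On these numbers compound 3 sits second highest of the three; its nearest neighbour is compound 2, and its furthest is compound 1, and both gaps lie within the scatter, so no order among the three can be read from them.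

The compound to be measured is compound 4 `Nc1ccc(-c2cc(=O)c3c(N)c(F)ccc3o2)cc1`. It differs from compound 3 in one place: hydrogen in place of fluoro on an aromatic carbon. The spot is on an aromatic carbon of the fused six-membered ring, para to an amino group.

Going by the values given here, one measured step bears on this: a halogen on an aromatic carbon of that same ring is replaced by hydrogen in the step from compound 1 to compound 2, which gave a 1.9-fold higher number from compound 1 to compound 2 (0.27 log units; within the scatter). That replacement did not move the number beyond the scatter. The change here is of the same kind, with a smaller halogen leaving, so no step beyond the scatter is expected in this assay, in either direction.

Compound 4 is therefore estimated at 6 nM, between 3 nM and 13 nM, corresponding to an expected step of no change at the digits printed from compound 3 to compound 4 (within the scatter).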

Compound 4, half-maximal inhibitory concentration: 4.4 nM
Beside the measured number, compound 4's estimate is 1.4-fold (0.13 log units) above it; the range from low to high includes it.
By their numbers in this assay, from the lowest: compounds 1, 4, 3 and 2 (each within the scatter of the next).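

In this assay, replacing the fluoro group para to an amino group with hydrogen gives a 1.4-fold lower number from compound 3 to compound 4 (0.13 log units; within the scatter), so compound 3's second fluoro group brings no change that can be told from the scatter. Compound 4 also completes a small set at one aromatic carbon of the shared core, which carries hydrogen in compound 2, fluoro in compound 4 and chloro in compound 1: the steps are a 1.7-fold lower number from compound 2 to compound 4 (0.22 log units; within the scatter) and a 1.1-fold higher number from compound 1 to compound 4 (0.05 log units; within the scatter), and neither these nor the earlier step between hydrogen and chloro leave the scatter, so these three atoms cannot be told apart at that carbon in this assay. No measurement shown offers an explanation for why these exchanges leave the number within the scatter.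

The compounds shown carry only hydrogen, fluoro and chloro on these carbons, so they leave open whether a larger or different group, such as a methoxy group, a nitrile or a carboxylic acid, would shift the number beyond the scatter. They also leave open whether the same holds at the ring's other carbons, where a bromo group or a short alkyl chain could sit.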